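This account rests on a few compounds, and the source may have more. Where it says the series, first, only, none or still open, it means among the compounds named here.

Three compounds built on a shared core have numbers in an ADME assay on CEM-SS cells (Homo sapiens) for cytotoxicity, read by XTT assay, with a stated time of 6 days; a higher number here means that more compound is tolerated, a lower number that less compound is tolerated. Compound 1 (`CCCC(=O)OCSc1ccccc1C(=O)N[C@H]1CCC[C@@H]1C(N)=O`) gives 31.2 uM; 43.3 uM (2 entries), and compound 2 (`CCCC(=O)OCSc1ccccc1C(=O)N[C@H]1CCC[C@H]1C(N)=O`) gives 89.9 uM; 84.8 uM (2 entries). What separates these two is the fact that compounds 1 and 2 differ only in the configuration as drawn. Within the data shown here, compound 3 (`CCCC(=O)OCSc1ccccc1C(=O)N(C)CC(N)=O`) gives 55.3 uM, the only number available for it, since two further entries for compound 3 carry no single number.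

Compound 4 (`CCCC(=O)OCSc1ccccc1C(=O)NCC(=O)NC(C)C`) has not yet been measured. It departs from compound 3 as follows: ((isopropylcarbamoyl)methyl)amino in place of (carbamoylmethyl)(methyl)amino on a carbonyl carbon. In words, ((isopropylcarbamoyl)methyl)amino stands in place of (carbamoylmethyl)(methyl)amino on a carbonyl carbon.

Among the measured compounds shown here, no measured pair tests this exchange, so the expectation starts from compound 3 at 55.3 uM. The expected move, a 1.1-fold lower number from compound 3 to compound 4 (0.04 log units; within the scatter), is estimated to stay within the usual scatter, with no firm direction. The gap between compound 1 at 31.2 uM; 43.3 uM (2 entries) and compound 2 at 89.9 uM; 84.8 uM (2 entries) keeps the range wide. Compound 4 is expected at 50 uM, with an estimated range from 22 uM to 100 uM.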

Compound 4, half-maximal toxic concentration: 92 uM
Beside the measured number, compound 4's estimate is 1.8-fold (0.26 log units) below it, and the stated range covers the measured number.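

In this assay, among these compounds, putting ((isopropylcarbamoyl)methyl)amino in place of (carbamoylmethyl)(methyl)amino on a carbonyl carbon gives a 1.7-fold higher number from compound 3 to compound 4 (0.22 log units; within the scatter), a first reading of this exchange. Among the compounds shown here, this place therefore accepts a group of 8 heavy atoms instead of 6, with 2 hydrogen-bond donors instead of 1, without a step beyond the usual scatter, something the earlier compounds, none of which carries an isopropyl group, could not show. No measurement at hand bears on why the exchange reads this way.

The exchange alters the group in more than one way at once, so the compounds shown do not separate the methyl group leaving from the isopropyl group entering. As far as these compounds go, how a carboxylic acid, an amine or a longer chain would read at this place remains open.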